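The source may hold more compounds than are shown below. What is called first, only, known or untested is meant among the compounds shown, and "the series" means these compounds.

Measured compounds in an ADME assay on RAW264.7 cells (Mus musculus) for cytotoxicity, read by MTT assay, with a stated time of 24 h; on this read-out higher numbers stand for lower toxicity in this test and lower numbers for higher toxicity in this test:
- compound 1 `COc1ccccc1C(=O)Nc1ccc(Cl)cc1F` gives > 40000 nM, a limit of the assay.
- compound 2 `O=C(Nc1ccc(Cl)cc1F)c1ccccc1OCc1ccc(F)cc1F` gives > 40000 nM, a limit of the assay.
- compound 3 `O=c1oc2ccccc2c(=O)n1-c1ccc(Cl)cc1F` gives 26500 nM.

Compound 1 stands at the limit; its value is only a limit, as is one of the other two, so it cannot be placed against them by a number. For the measured compounds named here, compound 3 alone gives a figure, and no step to it is readable. Going by the values given here, the one measured step, a step that the two limits leave unreadable from compound 1 to compound 2, is unreadable for the same reason, see (the limit of > 40000 nM in this assay, at which 2 of the 3 values shown sit).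

Compound 4 `O=C(Nc1ccc(Cl)cc1F)c1ccccc1` differs from compound 1 by hydrogen in place of methoxy on an aromatic carbon. Among the compounds with values here, no measured step bears on this change, so no direction can be read from the series. For this assay the expectation is therefore a step of a number no higher from compound 1 to compound 4 (the limit leaves the size open), within the scatter, and compound 4 is estimated at 40000 nM (range 20000 nM to 80000 nM), most likely reported again as a limit.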

Compound 4, half-maximal cytotoxic concentration: > 40000 nM
Compound 4: no number, only a limit; the forecaster's own chance of this, stated with the estimate: 70%; the middle value lies on the limit itself.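

In this assay compound 4 gives > 40000 nM, a limit of the assay, so no step from compound 1 can be read: the limit of > 40000 nM in this assay, at which 3 of the 4 values shown sit.

The compounds shown leave open whether methoxy or hydrogen on that aromatic carbon makes any difference to the read-out.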